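Fluorophenyl to Cyclohexyl at the Benzylic Position

The compounds below may be only part of what the source reports. "The series", "measured", "known", "first", "only" and "open" are said of these compounds alone.

Of the compounds shown here, three with a shared core have been measured in a physicochemical assay for solubility, with a stated time of 18 h, at pH 7.4; on this read-out higher numbers stand for higher solubility and lower numbers for lower solubility. Compound 1 `Cc1cc(C)cc(Cc2ccc3c(NCCCNCc4ccco4)ccnc3c2)c1` gives 4200 nM in this assay. Compound 2 `COc1ccc(Oc2ccc3c(NCCCNCc4ccco4)ccnc3c2)cc1` gives 14500 nM. Compound 3 `Fc1ccc(Cc2ccc3c(NCCCNCc4ccco4)ccnc3c2)cc1` gives 4200 nM. Compound 3 stands level with compound 1 at the digits shown, and these two together hold the lowest of the three numbers, while compound 2 lies furthest from them. The step of a 3.5-fold lower number from compound 2 to compound 3 (0.54 log units; beyond the scatter) is modest but beyond the scatter, as is the step of a 3.5-fold higher number from compound 1 to compound 2 (0.54 log units; beyond the scatter); the step of no change at the digits printed from compound 1 to compound 3 (within the scatter) stays within the scatter.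

Compound 4 `c1coc(CNCCCNc2ccnc3cc(CC4CCCCC4)ccc23)c1` has not yet been measured. Its change from compound 3 is cyclohexyl in place of 4-fluorophenyl on a saturated chain carbon bound to an aromatic carbon. The measured step that bears on it most closely is the exchange of one ring for another at the same place, no change at the digits printed from compound 1 to compound 3 (within the scatter), which produced nothing beyond the scatter. Among the measured compounds shown here, no measured step swaps an aromatic ring for a non-aromatic one, so no ground for a larger move exists. The account expects a step of a 1.1-fold lower number from compound 3 to compound 4 (0.02 log units; within the scatter), within the scatter. Compound 4 is therefore estimated at 4000 nM, with a range from 1500 nM to 10000 nM.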

Compound 4, solubility: 4200 nM
For compound 4 the middle estimate is 1.1-fold (0.02 log units) below the measured one; measured number inside the range.
By their numbers in this assay, from the lowest: compounds 1, 3 and 4 (each within the scatter of the next); then compound 2.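

In this assay, the exchange of an aromatic ring for a non-aromatic one at this place, on a saturated chain carbon bound to an aromatic carbon, gives no change at the digits printed from compound 3 to compound 4 (within the scatter), and the fluorine leaves with the ring. The same holds against 3,5-dimethylphenyl, with no change at the digits printed from compound 1 to compound 4 (within the scatter), so that all three carbon rings at this place sit together, while the one gap seen so far remains, now as a 3.5-fold lower number from compound 2 to compound 4 (0.54 log units; beyond the scatter). No measurement at hand accounts for this sameness.

The compounds shown leave open whether the gap to compound 2 goes with the oxygen of its 4-methoxyphenoxy group or with the methoxy group itself. They also leave open whether an amine or a carboxylic acid on the cyclohexyl ring would move the number at all.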